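Carboxy on the pyridinyl amine: solubility working notes

The source may hold more compounds than are shown below. What is called first, only, known or untested is meant among the compounds shown, and "the series" means these compounds.

Three compounds of the series share one core, varied at the aryl fluorines and on the pyridinyl amine. Compound 1 `Fc1ccc(-c2nc3cnc(Nc4ccccn4)cc3[nH]2)cc1C(F)(F)F` carries trifluoromethyl on the aryl ring. In a physicochemical assay for solubility, using the shake flask method, in phosphate buffer, measured as kinetic solubility, with a stated time of 20 h, at pH 6.5 (on this read-out lower numbers stand for lower solubility and higher numbers for higher solubility), compound 1 gives only a limit, < 5000 nM. Compound 2 `Fc1ccc(-c2nc3cnc(Nc4ccccn4)cc3[nH]2)cc1F` has fluoro in its place. In this assay compound 2 also returns a limit, < 5000 nM. Compound 3 `Fc1ccc(-c2nc3cnc(Nc4cc(C(F)(F)F)ccn4)cc3[nH]2)cc1F` adds trifluoromethyl on the pyridinyl ring. In this assay compound 3 again sits at a limit, < 5000 nM.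

Both measured steps, a step that the two limits leave unreadable from compound 1 to compound 2 and a step that the two limits leave unreadable from compound 2 to compound 3, are therefore unreadable in size, since the limit of < 5000 nM in this assay, at which 3 of the 3 values shown sit: no direction can be taken from them.

Compound 4 `O=C(O)c1ccc(Nc2cc3[nH]c(-c4ccc(F)c(F)c4)nc3cn2)nc1` differs from compound 2 by carboxy in place of hydrogen on an aromatic carbon. Neither measured step bears a readable size on this change, so the expectation rests only on the fact that compound 2 stands at a limit, < 5000 nM, and that a step of any size may lie behind it. Compound 4 is estimated at 20000 nM, with a range from 3000 nM to 120000 nM, which means an expected step of an at least 4.0-fold higher number from compound 2 to compound 4 (0.60 log units; beyond the scatter) in this assay, upward beyond the scatter, though a further limit reading remains a real possibility.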

Compound 4, solubility: 7000 nM
Beside the measured number, compound 4's estimate is 2.9-fold (0.46 log units) above it, within the range that was stated.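

Of the four compounds shown, compound 4 alone gives a number rather than a limit in this assay, so 5-carboxypyridin-2-yl in place of pyridin-2-yl yields a reading where the other compounds give none. The change reads as an at least 1.4-fold higher number from compound 2 to compound 4 (0.14 log units; that floor lies within the scatter); that floor does not by itself establish a gain beyond the usual scatter, though the true step may be larger. This place on the pyridinyl ring, two atoms from the ring nitrogen and para to a large group, is therefore the only one shown to carry a substituent with a measured value, while the earlier steps remain unreadable, held by a single limit: the limit of < 5000 nM in this assay, at which 3 of the 4 values shown sit.

As far as these compounds go, it remains open whether the reading belongs to carboxy itself or would also follow from another group at this place, such as an amine, a methyl ester or a primary amide. From the compounds shown here alone, it also remains open whether carboxy would give a measured value with the trifluoromethyl aryl ring of compound 1, or whether a longer chain ending in a carboxylic acid would read alike.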